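From thiophen-2-yl to 1-benzofuran-2-yl: working notes on compound 3

The source may hold more compounds than are shown below. What is called first, only, known or untested is meant among the compounds shown, and "the series" means these compounds.

Measured so far in a functional assay on CEM-DNR-bulk cells (Homo sapiens), read by MTT assay, with a stated time of 72 h; on this read-out lower numbers stand for stronger inhibition and higher numbers for weaker inhibition:
- compound 1 `Cc1ncnc2c1c(-c1ccoc1)cn2[C@@H]1O[C@H](CO)[C@@H](O)[C@H]1O`: > 20000 nM, a limit
- compound 2 `Cc1ncnc2c1c(-c1cccs1)cn2[C@@H]1O[C@H](CO)[C@@H](O)[C@H]1O`: > 20000 nM, a limit

Compound 2 has no number in this assay, only a limit, and the other measured compound stands in the same way: the limit of > 20000 nM in this assay, at which 2 of the 2 values shown sit. The next structure is compound 3 `Cc1ncnc2c1c(-c1cc3ccccc3o1)cn2[C@@H]1O[C@H](CO)[C@@H](O)[C@H]1O`, which keeps the core of compound 2 and changes one group: 1-benzofuran-2-yl in place of thiophen-2-yl on an aromatic carbon. Within the data shown here, the only measured step that bears on this change is a step that the two limits leave unreadable from compound 1 to compound 2. Among the measured compounds shown here, that step exchanges one five-membered aromatic ring for another, and no measured compound carries a six-membered aromatic ring of carbon only on this position. The series therefore offers no readable size to carry over, and no step beyond the scatter is expected in this assay, in either direction. The most likely outcome is that compound 3 is again reported only as a limit. The expected change is a number no higher from compound 2 to compound 3 (the limit leaves the size open). For compound 3 the estimated value is 20000 nM. The expected range for compound 3 runs from 7000 nM to 40000 nM.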

Compound 3, half-maximal inhibitory concentration: > 20000 nM
Compound 3 was reported as a limit; the forecaster's own chance of this, stated with the estimate: 80%; the middle value lies on the limit itself.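

In this assay compound 3 gives > 20000 nM, a limit and not a number. No step can be read among compound 1, compound 2 and compound 3, which all stand in the same way: the limit of > 20000 nM in this assay, at which 3 of the 3 values shown sit.

The compounds shown leave open how furan-3-yl, thiophen-2-yl and 1-benzofuran-2-yl rank in this assay, and whether any group on the shared core gives a readable number.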